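The compounds below may be only part of what the source reports. "The series", "measured", "known", "first", "only" and "open" are said of these compounds alone.

Compounds measured so far:
- Compound 1, `COc1ccc2c(=O)c(/C=C/C(=O)Nc3ccccc3)coc2c1`: > 100000 nM
- Compound 2, `COc1ccc2c(=O)c(/C=C/C(=O)NCc3ccc(C)cc3)coc2c1`: > 100000 nM
- Compound 3, `COc1ccc2c(=O)c(/C=C/C(=O)Nc3ccccc3C)coc2c1`: 7270 nM

Of the compounds shown here, three sharing one core have been tested in a functional assay on HeLa cells (Homo sapiens) for inhibition, read by MTT assay, with a stated time of 48 h; a higher number here means a weaker inhibitor, a lower number a stronger inhibitor. In this assay compound 1 gives > 100000 nM, which is a limit of the assay and not a number. Compound 2 likewise gives > 100000 nM, again a limit rather than a number. For the measured compounds named here, compound 3 is therefore the only compound with a measured number, and it stands as the single readable value among the three. The change from compound 1 to compound 3, methyl in place of hydrogen on an aromatic carbon, gives an at least 13-fold lower number from compound 1 to compound 3 (1.13 log units; beyond the scatter), and the change from compound 2 to compound 3 gives an at least 13-fold lower number from compound 2 to compound 3 (1.13 log units; beyond the scatter); both steps are read against (the limit of > 100000 nM in this assay, at which 2 of the 3 values shown sit).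

Compound 4, `COc1ccc2c(=O)c(/C=C/C(=O)Nc3ccccc3Cl)coc2c1`, has not yet been measured. It differs from compound 3 by chloro in place of methyl on an aromatic carbon. The change leaves one heavy atom and brings in one heavy atom, placed ortho to a large group, so the group sits where the methyl of compound 3 sat. Going by the values given here, no measured step compares chloro with methyl, so the expectation rests on compound 3 alone. The step is expected to be small, a 1.0-fold lower number from compound 3 to compound 4 (0.02 log units; within the scatter), with no clear direction. Compound 4 is therefore estimated at 7000 nM, within a range of 2500 nM to 25000 nM.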

Compound 4, half-maximal inhibitory concentration: 22400 nM
Beside the measured number, compound 4's estimate is 3.2-fold (0.51 log units) below it, and the stated range covers the measured number.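

In this assay, the aromatic carbon ortho to a large group proves sensitive to which group it carries. Methyl and chloro each count as one heavy atom, yet the exchange gives a 3.1-fold higher number from compound 3 to compound 4 (0.49 log units; beyond the scatter), so the group's identity matters here and not only the presence of a single atom. Chloro also shows that methyl is not the only group at this place to give a readable number, with an at least 4.4-fold lower number from compound 1 to compound 4 (0.64 log units; beyond the scatter) on replacing hydrogen and an at least 4.4-fold lower number from compound 2 to compound 4 (0.64 log units; beyond the scatter) on replacing the whole 4-methylbenzyl group with 2-chlorophenyl, though compound 1 and compound 2 each stand at a limit of the assay and not at a number, so these two steps give only a minimum size: the limit of > 100000 nM in this assay, at which 2 of the 4 values shown sit.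

On these data alone, with only hydrogen, methyl and chloro at this place, it remains open whether fluoro, methoxy or trifluoromethyl would follow methyl, chloro or neither. As far as these compounds go, the two groups are also compared at this one place only, so it is unknown whether the gap between 2-methylphenyl and 2-chlorophenyl would hold on another carbon of the ring, and the numbers do not say why the two groups differ.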